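Benzyloxycarbonyl for Methyl on a Second Core

A few compounds are considered here, and "the series" means these few. Any claim that something is new, unique, unknown or untested is made for them only; others in the source may bear on it.

Compound 1, `Cc1ccc2[nH]c(-c3cn(-c4ccccc4)nc3-c3ccc(Cl)cc3)nc2c1`, gives 4640 nM in a functional assay on A549 cells (Homo sapiens) for antiproliferative activity, read by MTT assay, with a stated time of 48 h; on this read-out lower numbers stand for stronger inhibition and higher numbers for weaker inhibition.
Compound 2, `O=C(OCc1ccccc1)c1ccc2[nH]c(-c3cn(-c4ccccc4)nc3-c3ccc(Cl)cc3)nc2c1`, gives 7730 nM in this assay.
Compound 3, `COc1ccc(-c2nn(-c3ccccc3)cc2-c2nc3cc(C)ccc3[nH]2)cc1`, gives 5070 nM in this assay.

Compound 1 and compound 2 differ in one place: benzyloxycarbonyl in place of methyl on an aromatic carbon. This change produced a 1.7-fold higher number from compound 1 to compound 2 (0.22 log units; within the scatter), so the two values are not told apart by the measurement. Compound 3 carries a different core, and the difference from the core of compound 1 is methoxy in place of chloro on an aromatic carbon, a change that gave a 1.1-fold higher number from compound 1 to compound 3 (0.04 log units; within the scatter).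

Compound 4, `COc1ccc(-c2nn(-c3ccccc3)cc2-c2nc3cc(C(=O)OCc4ccccc4)ccc3[nH]2)cc1`, has not yet been tested in this assay. It differs from compound 3 in exactly the way compound 2 differs from compound 1: benzyloxycarbonyl in place of methyl on an aromatic carbon. The place of the change reads the same for both pairs, so it counts as the same change on a second core.

Because a 1.7-fold higher number from compound 1 to compound 2 (0.22 log units; within the scatter) stayed within the scatter, the expectation for compound 4 is a step of similar size, a 1.7-fold higher number from compound 3 to compound 4 (0.22 log units; within the scatter), and an estimated value near 8500 nM, with a likely range from 4000 nM to 18000 nM.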

Compound 4, half-maximal inhibitory concentration: 11900 nM
For compound 4 the middle estimate is 1.4-fold (0.15 log units) below the measured one, and the stated range covers the measured number.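

In this assay, benzyloxycarbonyl in place of methyl on the second core gave a 2.3-fold higher number from compound 3 to compound 4 (0.37 log units; beyond the scatter), and this step agrees with the one seen on the first core: the same change on two cores in this assay, a 1.7-fold higher number (0.22 log units; within the scatter) from compound 1 to compound 2 and a 2.3-fold higher number (0.37 log units; beyond the scatter) from compound 3 to compound 4, 1.4-fold (0.15 log units) apart, within the scatter of two such steps. Methoxy in place of chloro, read here on the two benzyloxycarbonyl compounds, gave a 1.5-fold higher number from compound 2 to compound 4 (0.19 log units; within the scatter), and this change also carries over: the same change on two cores in this assay, a 1.1-fold higher number (0.04 log units; within the scatter) from compound 1 to compound 3 and a 1.5-fold higher number (0.19 log units; within the scatter) from compound 2 to compound 4, 1.4-fold (0.15 log units) apart, within the scatter of two such steps. These four compounds show that both changes kept a similar size on the two cores in this one assay, but they do not show why the steps have this size or whether a third core would behave alike.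

The compounds shown carry only methyl or benzyloxycarbonyl at the changed place, so it remains open what a carboxylic acid, an amine or a simple methyl ester would give there. On the other aromatic ring only chloro and methoxy appear, which leaves groups such as fluoro or nitrile still to be compared.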